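Fluoro step repeated on a second core, HeLa cytotoxicity

The source may hold more compounds than are shown below. What is called first, only, known or untested is meant among the compounds shown, and "the series" means these compounds.

Compound 1 `CC(=O)c1cc(-c2ccccc2)cc2cc(-c3ccccc3)[nH]c12` carries a phenyl group on the shared core; in a functional assay on HeLa cells (Homo sapiens) for cytotoxicity, read by MTT assay, with a stated time of 2 days, tested at 0.1 uM (a higher number here means a weaker effect of the compound at the concentration tested, a lower number a stronger effect), compound 1 gives 72.3%. Compound 2 `CC(=O)c1cc(-c2ccc(F)cc2)cc2cc(-c3ccccc3)[nH]c12` differs from compound 1 by fluoro in place of hydrogen on an aromatic carbon and in this assay compound 2 gives 90.3%, a step of a number 18 percentage points higher from compound 1 to compound 2 (beyond the scatter). Compound 3 `CC(=O)c1cc(/C=C/c2ccccc2)cc2cc(-c3ccccc3)[nH]c12` differs from compound 1 by 2-phenylethenyl in place of phenyl on an aromatic carbon. In this assay compound 3 gives 99.1%; the step is a number 26.8 percentage points higher from compound 1 to compound 3 (beyond the scatter), and against compound 2 it is a number 8.8 percentage points higher from compound 2 to compound 3 (within the scatter), so compounds 2 and 3 cannot be told apart here.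

Compound 4 `CC(=O)c1cc(/C=C/c2ccccc2)cc2cc(-c3ccc(F)cc3)[nH]c12` is not yet measured in this assay. It differs from compound 3 by fluoro in place of hydrogen on an aromatic carbon. This is the same change as the one from compound 1 to compound 2, at a place described in the same words, but it is now set on the core of compound 3, which differs from the core of compound 1 as given above. The earlier occurrence of the change moved the read-out by a number 18 percentage points higher from compound 1 to compound 2 (beyond the scatter). The value of compound 3, 99.1%, already lies close to the level of no effect at the tested concentration, so a second step of that size has little room. The step from compound 3 to compound 4 is therefore expected to be small, a number 0.1 percentage points lower from compound 3 to compound 4 (within the scatter), because compound 3 sits at 99.1%. For compound 4 the estimated value in this assay is 99%, expected to fall between 91% and 106%.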

Compound 4, a percentage reported as activity, at one concentration (the size of the read-out at that concentration, not a potency): 82.2%
The estimate for compound 4 lay 16.8 percentage points above the measured number; the measured number lies below the stated range.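

In this assay the step of a number 16.9 percentage points lower from compound 3 to compound 4 (beyond the scatter) runs in the opposite direction to the earlier step of the same description, so neither the direction nor the size of the fluoro change carried over from one core to the other: the same change on two cores in this assay, a number 18 percentage points higher (beyond the scatter) from compound 1 to compound 2 and a number 16.9 percentage points lower (beyond the scatter) from compound 3 to compound 4, 34.9 percentage points apart, beyond the scatter of two such steps. Among these compounds, this is not a strict repeat of one change on two cores: in compound 2 the fluoro stands on the phenyl that compound 3 exchanges for 2-phenylethenyl, whereas in compound 4 it stands on the other phenyl, the one that compound 1 and compound 3 share. The result therefore shows that the earlier step cannot be used to predict this one, but it gives no cause for the reversal, and two pairs, each read at a single concentration, set no rule for the series and say nothing about potency.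

Still open, on these data alone, is whether the 4-fluorophenyl of compound 4 would give a similar step on the core of compound 1, where the 2-phenylethenyl is absent. Also open, as far as these compounds go, is how chloro, methoxy or an amine in place of that fluoro would behave, and what a carboxylic acid in place of the acetyl group would do to the read-out.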